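Furan to naphthalene on the pyrrole core of compound 2

A few compounds are considered here, and "the series" means these few. Any claim that something is new, unique, unknown or untested is made for them only; others in the source may bear on it.

The shared core carries a phenyl group, two furan-2-yl groups and an acetamide arm. Compound 1 `O=C(Cn1c(-c2ccccc2)cc(-c2ccco2)c1-c1ccco1)Nc1nc2ccccc2s1` gives 65.1% in an ADME assay on HEK-293T cells (Homo sapiens) for cytotoxicity, read by MTT assay, with a stated time of 72 h, tested at 50 uM (a lower number here means less inhibition, a higher number more inhibition at the concentration tested (going by the name of the read-out)), and compound 2 `CCc1nnc(NC(=O)Cn2c(-c3ccccc3)cc(-c3ccco3)c2-c2ccco2)s1` gives 90.2%, the higher of the two numbers, a step of a number 25.1 percentage points higher from compound 1 to compound 2 (beyond the scatter). Compound 3 `CCc1nnc(NC(=O)Cn2c(-c3ccccc3)cc(-c3cccc4ccccc34)c2-c2ccco2)s1` differs from compound 2 by naphthalen-1-yl in place of furan-2-yl on an aromatic carbon. Going by the values given here, the only measured step concerns the group on the amide nitrogen and is at a different place, so no measured step bears on this change and the data give no guide for it. Compound 2 already stands near the top of the range, so from compound 2 to compound 3 a step of a number 4.2 percentage points lower from compound 2 to compound 3 (within the scatter) is expected, that is no change beyond the scatter, with wide uncertainty. Compound 3 is therefore estimated at 86%, between 65% and 98%.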

Compound 3, a percentage reported as inhibition, at one concentration (the size of the read-out at that concentration, not a potency): 59.7%
Compound 3: middle estimate off by 26.3 percentage points, on the high side, outside the stated range (below it).
By their numbers in this assay, from the lowest: compounds 3 and 1 (each within the scatter of the next); then compound 2.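

In this assay the aromatic carbon that carries furan-2-yl turns out to be sensitive to the group placed there: naphthalen-1-yl in its place brings a number 30.5 percentage points lower from compound 2 to compound 3 (beyond the scatter) and so undoes the high number of compound 2. Going by these compounds alone, until now the only measured change lay at the group on the amide nitrogen, and this result shows that a change on the shared core itself can also move the number beyond the scatter. Nothing at hand explains the fall.

The compounds shown leave open whether a smaller group at this position, such as a thiophene ring or a single benzene ring, would stay close to compound 2 or fall towards compound 3. They also leave open whether the same change would act alike with 1,3-benzothiazol-2-yl on the amide nitrogen.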